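Microsomal half-life on changing the group at the sulfonyl sulfur

The compounds below may be only part of what the source reports. "The series", "measured", "known", "first", "only" and "open" are said of these compounds alone.

Compound 1 `O=C([C@@H]1CCCN(S(=O)(=O)c2ccc(S(=O)(=O)N3CC[C@@H](O)C3)cc2)C1)N1CCC(F)(F)CC1`: in an ADME assay on microsomes from liver (Homo sapiens) for metabolic stability, read by LC-MS, using NADPH, with a stated time of 60 min, tested at 10 uM (on this read-out higher numbers stand for a longer-lived compound and lower numbers for a shorter-lived compound), compound 1 gives 0.517 h.
Compound 2 `CCC(CC)S(=O)(=O)c1ccc(S(=O)(=O)N2CCC[C@@H](C(=O)N3CCC(F)(F)CC3)C2)cc1`: in this assay compound 2 gives 0.285 h.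
Compound 3 `CN(C)S(=O)(=O)c1ccc(S(=O)(=O)N2CCC[C@@H](C(=O)N3CCC(F)(F)CC3)C2)cc1`: in this assay compound 3 returns > 1 h, which is a limit of the assay and not a number.

Compound 3 is thus known only through a limit (the limit of > 1 h in this assay, at which 1 of the 3 values shown sits); how far its half-life lies beyond that limit is open. Compound 4 `CC(C)NS(=O)(=O)c1ccc(S(=O)(=O)N2CCC[C@@H](C(=O)N3CCC(F)(F)CC3)C2)cc1` differs from it in one place: isopropylamino in place of dimethylamino on a sulfonyl sulfur. Two measured steps end at the dimethylamino group and bear on this change. an at least 3.5-fold higher number from compound 2 to compound 3 (0.54 log units; beyond the scatter). an at least 1.9-fold higher number from compound 1 to compound 3 (0.28 log units; that floor lies within the scatter). Both replace pentan-3-yl or 3-hydroxypyrrolidin-1-yl on the sulfonyl sulfur with dimethylamino and both run upward, the second only to its floor. Among the measured compounds shown here, the step to compound 4 keeps a small open-chain amine on the sulfonyl sulfur and brings in a hydrogen-bond donor; no measured step isolates a change of that kind. In this assay no step beyond the scatter is therefore expected, a number no higher from compound 3 to compound 4 (the limit leaves the size open), and compound 4 may again return only the limit. Compound 4 is estimated at 1 h, within a range of 0.45 h to 2.2 h.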

Compound 4, half-life: 0.328 h
For compound 4 the middle estimate is 3.0-fold (0.48 log units) above the measured one; the measured number lies below the stated range.
By their numbers in this assay, from the lowest: compounds 2, 4 and 1 (each within the scatter of the next). At a limit, above all of these: compound 3.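

Keeping a small open-chain amine on the sulfonyl sulfur is not enough to hold the half-life: in this assay, isopropylamino in place of dimethylamino gives an at least 3.0-fold lower number from compound 3 to compound 4 (0.48 log units; beyond the scatter). Compound 4 is not separated from the other two measured compounds, with a 1.2-fold higher number from compound 2 to compound 4 (0.06 log units; within the scatter) and a 1.6-fold lower number from compound 1 to compound 4 (0.20 log units; within the scatter), so dimethylamino alone stands apart among the groups shown at this position. The value of compound 3 is a limit of the assay and not a number, so the size of its step remains a floor: the limit of > 1 h in this assay, at which 1 of the 4 values shown sits.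

The isopropyl chain and the hydrogen on the nitrogen enter together, and the compounds shown do not separate them. Where methylamino and diethylamino on the sulfonyl sulfur would fall, which could tell the two apart, remains open.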